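From methyl to fluoro: little change expected

A few compounds are considered here, and "the series" means these few. Any claim that something is new, unique, unknown or untested is made for them only; others in the source may bear on it.

In a functional assay on B16-F10 cells (Mus musculus) for antiproliferative activity, read by MTT assay, with a stated time of 48 h (on this read-out lower numbers stand for stronger inhibition and higher numbers for weaker inhibition), two compounds have been measured so far:
- compound 1 `COc1ccc(/C=C/c2cc(OC)cc(OC)c2/C=C/C(=O)c2ccc(C)cc2)cc1` gives 5.3 ug/mL
- compound 2 `COc1ccc(/C=C/c2cc(OC)cc(OC)c2/C=C/C(=O)c2cccc(Br)c2)cc1` gives 5.1 ug/mL

On these numbers compound 1 has no rank of its own. The only measured gap is a 1.0-fold lower number from compound 1 to compound 2 (0.02 log units; within the scatter) and it lies within the scatter, so compound 1 and compound 2 stand level.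

Attention now turns to compound 3 `COc1ccc(/C=C/c2cc(OC)cc(OC)c2/C=C/C(=O)c2ccc(F)cc2)cc1` which has not yet been measured. It differs from compound 1 by fluoro in place of methyl on an aromatic carbon, para to a large group (fluoro in place of methyl on an aromatic carbon). Among the compounds with values here, the one measured step that bears on this change is the gap just described, since it also replaces the 4-methylphenyl group, there with 3-bromophenyl. Within the data shown here, that step stayed within the scatter, but it is a single step, and no fluoro compound has been measured yet. No step beyond the scatter is therefore expected in this assay in either direction. The estimated step is a 1.0-fold higher number from compound 1 to compound 3 (0.02 log units; within the scatter) and it is expected to stay within the scatter. Compound 3 is expected at about 5.5 ug/mL (2.7 ug/mL to 11 ug/mL).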

Compound 3, half-maximal inhibitory concentration: 5.3 ug/mL
The estimate for compound 3 lay 1.0-fold (0.02 log units) above the measured number; low and high end bracket the measured number.
By their numbers in this assay, from the lowest: compounds 2, 1 and 3 (each within the scatter of the next).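

In this assay, fluoro in place of methyl on the same aromatic carbon, para to a large group, gives no change at the digits printed from compound 1 to compound 3 (within the scatter), so this single-atom exchange can be read at one place, whereas the earlier step had replaced 4-methylphenyl with 3-bromophenyl, a different group at a different place on the ring. The second new step, a 1.0-fold higher number from compound 2 to compound 3 (0.02 log units; within the scatter), shows that 4-fluorophenyl and 3-bromophenyl also stand level, so all three groups on the carbonyl carbon now lie within the scatter of one another in this small set. No measurement at hand explains why the read-out stays level across these exchanges.

Among the compounds shown, this ring carries only methyl, bromo or fluoro, so it remains open whether an amine, a carboxylic acid or a longer chain such as butyl in the place of the fluoro would also stay level. On these data alone, it also remains open whether a change elsewhere in the shared core would move the number further than any exchange on this ring has done so far.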